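The source may hold more compounds than are shown below. What is called first, only, known or untested is meant among the compounds shown, and "the series" means these compounds.

Compound 1, `CC(=N)N1CCC(Oc2ccc3c(c2)C(=O)NS(=O)(=O)N3Cc2ccc3ccc(C(=N)N)cc3c2)CC1`, and compound 2, `CC(=N)N1CCC(Oc2ccc3c(c2)C(=O)NS(=O)(=O)N3C/C=C/c2cccc(C(=N)N)c2)CC1`, share one core and differ in the group carried on the saturated chain carbon bound to the sulfonamide nitrogen in the ring. In an assay on isolated protein for inhibition of coagulation factor X (Mus musculus) (a higher number here means a weaker inhibitor, a lower number a stronger inhibitor), compound 1 gives 2.1 nM. In this assay compound 2 gives 2.8 nM. Of the two numbers, that of compound 2 is the higher one, but the gap to compound 1 lies within the scatter of repeated measurements, so the two compounds cannot be told apart on these data.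

Compound 3, `CC(=N)N1CCC(Oc2ccc3c(c2)C(=O)NS(=O)(=O)N3CC(=O)Nc2cccc(C(=N)N)c2)CC1`, has not been measured. It differs from compound 2 in one place: a group of 12 heavy atoms (8 carbon, 3 nitrogen, 1 oxygen; one six-membered aromatic ring of carbon only) in place of a group of 11 heavy atoms (9 carbon, 2 nitrogen; one six-membered aromatic ring of carbon only), on a saturated chain carbon bound to a sulfonamide nitrogen in a ring. Within the data shown here, no pair of measured compounds shows what such a change does, so the size of the step can only be guessed. The two measured compounds sit close together, compound 2 at 2.8 nM, and a new linker may not hold that level. A modest loss is expected, with the step of a 2.9-fold higher number from compound 2 to compound 3 (0.46 log units; beyond the scatter). For compound 3 the estimate in this assay is 8 nM, with a range from 2 nM to 40 nM.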

Compound 3, half-maximal inhibitory concentration: 2.5 nM
Compound 3: middle estimate off by 3.2-fold (0.51 log units), on the high side; measured number inside the range.
By their numbers in this assay, from the lowest: compounds 1, 3 and 2 (each within the scatter of the next).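

In this assay, putting the group of 12 heavy atoms in place of the group of 11 heavy atoms, on a saturated chain carbon bound to a sulfonamide nitrogen in a ring, gives a 1.1-fold lower number from compound 2 to compound 3 (0.05 log units; within the scatter), so compound 2 and compound 3 cannot be told apart on these data. Among these compounds, this is the first step that can be read at this position, and it shows that the exchange can be made without a measurable shift in this number, even though the entering group has 3 hydrogen-bond donors and 2 hydrogen-bond acceptors where the leaving group has 2 and 1. Nothing available explains why the number holds across this change.

The compounds shown leave open whether this tolerance extends to other groups at this carbon, such as a longer chain between the carbonyl and the aromatic ring, or a methyl group on the amide nitrogen. They also leave open what happens when an aminomethyl group takes the place of the amidine on that aromatic ring.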